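Para-substituent swaps on a pyrazoline–pyrimidinone series

The source may report more compounds than this note shows. Statements on the series, on what has been measured and on what is new or still open speak of the compounds shown alone.

Compound 1 `COc1ccc(C2CC(c3ccccc3)=NN2c2nc(-c3ccccc3)c(C#N)c(=O)n2C)cc1` gives 18000 nM in a functional assay on MCF7 cells (Homo sapiens) for antiproliferative activity, with a stated time of 72 h; a lower number here means a stronger inhibitor, a higher number a weaker inhibitor. Compound 2 `Cn1c(N2N=C(c3ccccc3)CC2c2ccc(F)cc2)nc(-c2ccccc2)c(C#N)c1=O` differs from it by fluoro in place of methoxy on an aromatic carbon and gives 38100 nM; the step of a 2.1-fold higher number from compound 1 to compound 2 (0.33 log units; beyond the scatter). Compound 3 `COc1ccc(C2CC(c3ccccc3)=NN2c2nc(-c3ccc(Cl)cc3)c(C#N)c(=O)n2C)cc1` carries a different core, the difference being (chloro in place of hydrogen on an aromatic carbon); compound 3 gives 52400 nM, the step being a 2.9-fold higher number from compound 1 to compound 3 (0.46 log units; beyond the scatter). Compound 4 `Cn1c(N2N=C(c3ccccc3)CC2c2ccc(F)cc2)nc(-c2ccc(Cl)cc2)c(C#N)c1=O` is not yet measured; it stands to compound 3 as compound 2 stands to compound 1, the change being (fluoro in place of methoxy on an aromatic carbon), at the same place, so it is the same change on the other core. The step from compound 3 to compound 4 is expected to resemble the measured one, a 2.0-fold higher number from compound 3 to compound 4 (0.30 log units; within the scatter) beside a 2.1-fold higher number from compound 1 to compound 2 (0.33 log units; beyond the scatter), resting on that single pair. Compound 4 is therefore expected to give 105000 nM in this assay, estimated between 50000 nM and 220000 nM.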

Compound 4, half-maximal inhibitory concentration: 36800 nM
For compound 4 the middle estimate is 2.9-fold (0.46 log units) above the measured one, and the stated range ends above it.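

In this assay, fluoro in place of methoxy gives a 1.4-fold lower number from compound 3 to compound 4 (0.15 log units; within the scatter), so the change measured on the core of compound 1 does not carry over to the chloro-bearing core: the same change on two cores in this assay, a 2.1-fold higher number (0.33 log units; beyond the scatter) from compound 1 to compound 2 and a 1.4-fold lower number (0.15 log units; within the scatter) from compound 3 to compound 4, 3.0-fold (0.48 log units) apart, beyond the scatter of two such steps

Read the other way, chloro in place of hydrogen gives a 1.0-fold lower number from compound 2 to compound 4 (0.02 log units; within the scatter), so that change also depends on its partner: the same change on two cores in this assay, a 2.9-fold higher number (0.46 log units; beyond the scatter) from compound 1 to compound 3 and a 1.0-fold lower number (0.02 log units; within the scatter) from compound 2 to compound 4, 3.0-fold (0.48 log units) apart, beyond the scatter of two such steps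

This shows that the two changes are not additive across these four compounds, but with one pair per core, it sets no rule for the series and gives no cause.

Still open, as far as these compounds go, is whether the same dependence appears with other groups at the 4-methoxyphenyl position. An amine or a longer chain such as ethoxy would test this on both cores.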